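The source may report more compounds than this note shows. Statements on the series, on what has been measured and on what is new or still open speak of the compounds shown alone.

The series shares one core, varied only at a single position on the benzoyl ring. In an assay with adenosine receptor A1 (Rattus norvegicus) as the target (on this read-out higher numbers stand for an effect only at larger amounts of compound and lower numbers for an effect already at smaller amounts), compound 1 `Nc1sc2c(c1C(=O)c1ccc(C(F)(F)F)cc1)CCCC2` gives 4700 nM. Compound 2 `Nc1sc2c(c1C(=O)c1ccc(Cl)cc1)CCCC2` gives 6800 nM in this assay. Compound 3 `Nc1sc2c(c1C(=O)c1ccc(I)cc1)CCCC2` gives 4500 nM in this assay. The three numbers do not separate from one another: a 1.4-fold higher number from compound 1 to compound 2 (0.16 log units; within the scatter), a 1.0-fold lower number from compound 1 to compound 3 (0.02 log units; within the scatter) and a 1.5-fold lower number from compound 2 to compound 3 (0.18 log units; within the scatter) all lie within the scatter, so compound 3 stands together with compound 1 and compound 2 rather than apart from them.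

Compound 4 `Cc1ccc(C(=O)c2c(N)sc3c2CCCC3)cc1` carries methyl in place of iodo on an aromatic carbon. For the measured compounds named here, no measured step involves a methyl group, so the only bearing comes from the three exchanges already made at this position, every one of which stayed within the scatter. On that basis the step from compound 3 to compound 4 in this assay is expected to be small, that is, a 1.1-fold higher number from compound 3 to compound 4 (0.05 log units; within the scatter), with no direction that can be supported. Compound 4 is therefore estimated at 5000 nM, with a range from 2000 nM to 13000 nM.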

Compound 4, half-maximal effective concentration: 34900 nM
For compound 4 the middle estimate is 7.0-fold (0.84 log units) below the measured one, outside the stated range (above it).
By their numbers in this assay, from the lowest: compounds 3, 1 and 2 (each within the scatter of the next); then compound 4.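

In this assay, for the compounds shown here, this position proves not to be indifferent to what it carries: methyl is the first exchange here to leave the scatter, with a 7.8-fold higher number from compound 3 to compound 4 (0.89 log units; beyond the scatter) and a 5.1-fold higher number from compound 2 to compound 4 (0.71 log units; beyond the scatter) and a 7.4-fold higher number from compound 1 to compound 4 (0.87 log units; beyond the scatter) all pointing the same way. Trifluoromethyl, chloro and iodo remain together, so among these four compounds methyl alone stands apart, needing larger amounts of compound for an effect. Nothing given here bears on why this exchange separates when the earlier ones did not.

Going by these compounds, whether the separation belongs to methyl alone or extends to a longer chain such as ethyl, to methoxy or to an amine remains open. As only this position varies among the compounds shown, it also remains open whether the methyl step would hold on an altered core.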